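A Methoxy Variant of Compound 2, Estimated Before Measurement

The compounds below may be only part of what the source reports. "The series", "measured", "known", "first", "only" and "open" are said of these compounds alone.

Of the compounds shown here, two sharing one core have been measured in a functional assay on UACC-62 cells (Homo sapiens) for cytotoxicity, read by sulforhodamine B assay; a lower number here means a stronger inhibitor of growth, a higher number a weaker inhibitor of growth. Compound 1 `CC1=CC[C@@H]([C@@](C)(O)CCCC(C)(C)NC(=S)NN)CC1` gives 18500 nM. Compound 2 `CC1=CC[C@@H]([C@@](C)(O)CCCC(C)(C)NC(=S)N/N=C\c2ccc(C)cc2)CC1`, which carries a larger group on the amide-type nitrogen, gives 11600 nM. Within the data shown here, the step of a 1.6-fold lower number from compound 1 to compound 2 (0.20 log units; within the scatter) is the only measured change, and it stays within the scatter. Compound 2 thus shows the lower of the two numbers, but its gap to compound 1 is too small to call it the stronger inhibitor of growth.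

Compound 3 `COc1ccc(/C=N\NC(=S)NC(C)(C)CCC[C@](C)(O)[C@@H]2CC=C(C)CC2)cc1` has not yet been measured. It differs from compound 2 by methoxy in place of methyl on an aromatic carbon. Among the measured compounds shown here, no measured step touches this position, so the expectation rests only on the small size of the single step seen so far. Compound 3 is expected to give about 11000 nM, between 4000 nM and 30000 nM, in this assay. The expected step of a 1.1-fold lower number from compound 2 to compound 3 (0.02 log units; within the scatter) lies within the scatter.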

Compound 3, concentration for 50% growth inhibition: 7420 nM
Beside the measured number, compound 3's estimate is 1.5-fold (0.17 log units) above it, and the stated range covers the measured number.
By their numbers in this assay, from the lowest: compounds 3, 2 and 1 (each within the scatter of the next, the first and the last beyond it).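

In this assay, going from 4-methylphenyl to 4-methoxyphenyl gives a 1.6-fold lower number from compound 2 to compound 3 (0.19 log units; within the scatter) and so does not separate the two compounds, which shows that methoxy in place of methyl at this place, para to a large group, leaves the number within the scatter. Against compound 1, however, the larger group carrying methoxy gives a 2.5-fold lower number from compound 1 to compound 3 (0.40 log units; beyond the scatter) as a modest step, whereas the step from compound 1 to compound 2 stayed within the scatter. Nothing measured here gives a reason for either step.

Still open, on these data alone, is whether a group of another kind at this same place, such as a chlorine atom, a nitrile or a dimethylamino group, would give a step beyond the scatter from compound 2. Also open, as far as these compounds go, is how a phenyl ring carrying no group at all would compare.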